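The source may hold more compounds than are shown below. What is called first, only, known or untested is meant among the compounds shown, and "the series" means these compounds.

Compound 2 `CCCCCc1ccc(-c2cn(C/C=C3\OC(=O)C(OCc4ccccc4)=C3OCc3ccccc3)nn2)cc1` stands at the edge of what a functional assay on HeLa cells (Homo sapiens) for antiproliferative activity, read by MTT assay, with a stated time of 72 h (a higher number here means a weaker inhibitor, a lower number a stronger inhibitor), reports: in this assay compound 2 gives only > 100000 nM, which is a limit rather than a number (the limit of > 100000 nM in this assay, at which 1 of the 3 values shown sits). Compound 1 `O=C1O/C(=C\Cn2cc(-c3cc(F)cc(F)c3)nn2)C(OCc2ccccc2)=C1OCc1ccccc1` gives 17700 nM in this assay, and compound 3 `O=C1O[C@H]([C@@H](O)Cn2cc(-c3cc(F)cc(F)c3)nn2)C(OCc2ccccc2)=C1OCc1ccccc1`, which also bears 3,5-difluorophenyl, gives 40800 nM. Among the compounds with values here, the single measured step that bears on the change, an at least 5.6-fold higher number from compound 1 to compound 2 (0.75 log units; beyond the scatter), lies beyond the scatter. Compound 4 `O=C1O/C(=C\Cn2cc(-c3cccc(O)c3)nn2)C(OCc2ccccc2)=C1OCc1ccccc1` carries 3-hydroxyphenyl in place of 4-pentylphenyl on an aromatic carbon. Since this moves away from 4-pentylphenyl, the group that accompanied the rise from compound 1 to compound 2, a lower number is expected for compound 4 in this assay, an at least 3.3-fold lower number from compound 2 to compound 4 (0.52 log units; beyond the scatter). Compound 4 is therefore estimated at 30000 nM, within a range of 10000 nM to 100000 nM.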

Compound 4, half-maximal inhibitory concentration: 74800 nM
Compound 4: middle estimate off by 2.5-fold (0.40 log units), on the low side, within the range that was stated.
By their numbers in this assay, from the lowest: compound 1; then compounds 3 and 4 (each within the scatter of the next). At a limit, above all of these: compound 2.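

In this assay the change at this aromatic carbon gives a 4.2-fold higher number from compound 1 to compound 4 (0.63 log units; beyond the scatter) and so shows that a loss against 3,5-difluorophenyl does not require the larger 4-pentylphenyl group. Against 4-pentylphenyl itself, the 3-hydroxyphenyl group gives an at least 1.3-fold lower number from compound 2 to compound 4 (0.12 log units; that floor lies within the scatter) and so no firm gain. Compound 2 stands at a limit, so these two replacements cannot be placed in order: the limit of > 100000 nM in this assay, at which 1 of the 4 values shown sits.

As far as these compounds go, whether a single fluorine on the phenyl ring would retain the level of compound 1 remains open. So does how an amine, a carboxylic acid or a shorter alkyl chain would fare at this carbon.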